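The source may hold more compounds than are shown below. What is called first, only, known or untested is meant among the compounds shown, and "the series" means these compounds.

Compound 1 `COc1ccc2c(=O)c(/C=C/C(=O)Nc3ccc(C)cc3)coc2c1`: in a functional assay on L02 cells (Homo sapiens) for inhibition, read by MTT assay, with a stated time of 48 h (on this read-out higher numbers stand for weaker inhibition and lower numbers for stronger inhibition), compound 1 gives > 200000 nM, which is a limit of this assay.
Compound 2 `COc1ccc2c(=O)c(/C=C/C(=O)NCc3ccc(F)cc3)coc2c1`: in this assay compound 2 gives > 200000 nM, also a limit.
Compound 3 `COc1ccc(NC(=O)/C=C/c2coc3cc(OC)ccc3c2=O)cc1`: in this assay compound 3 gives > 200000 nM, again a limit.

Compound 3 thus stands exactly where the other two stand, at the limit of > 200000 nM in this assay, at which 3 of the 3 values shown sit; whether any of the three differs from the others cannot be read. The unmeasured compound 4 `COc1ccc2c(=O)c(/C=C/C(=O)Nc3ccccc3Cl)coc2c1` departs from compound 3 by 2-chlorophenyl in place of 4-methoxyphenyl on an amide-type nitrogen. The measured steps that touch the group on the amide-type nitrogen, a step that the two limits leave unreadable from compound 1 to compound 2 and a step that the two limits leave unreadable from compound 2 to compound 3, are unreadable, as is a step that the two limits leave unreadable from compound 1 to compound 3, methoxy in place of methyl on an aromatic carbon, so no size or direction can be drawn from them. Compound 4 is expected to sit at the limit as well, its estimated step that the limit leaves unreadable from compound 3 to compound 4 being a guess only. Compound 4 is estimated at 250000 nM, between 100000 nM and 1000000 nM.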

Compound 4, half-maximal inhibitory concentration: > 200000 nM
Compound 4 ended at the assay's limit; the forecaster's own chance of this, stated with the estimate: 85%; the middle value lies beyond the limit too.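

Compound 4 stops at a limit, so its steps to compound 1, compound 2 and compound 3 cannot be read: the limit of > 200000 nM in this assay, at which 4 of the 4 values shown sit. The compounds shown leave open whether any of the four differs from another in this assay.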